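The compounds below may be only part of what the source reports. "The series", "measured", "known", "first", "only" and "open" are said of these compounds alone.

Of the compounds shown here, three sharing one core have been measured in a functional assay on MIA PaCa-2 cells (Homo sapiens) for antiproliferative activity, read by sulforhodamine B assay, with a stated time of 48 h; a higher number here means a weaker inhibitor of growth, a lower number a stronger inhibitor of growth. Compound 1 `COc1ccc(Cn2cc(CNC(=O)c3cn(-c4ccccc4)nc3-c3ccccc3)nn2)cc1` gives 10200 nM in this assay. Compound 2 `COc1ccc(Cn2cc(CNC(=O)c3cn(-c4ccccc4)nc3-c3ccccc3)nn2)cc1OC`, which carries one more methoxy group, gives 8200 nM; the step of a 1.2-fold lower number from compound 1 to compound 2 (0.09 log units; within the scatter) is too small to count as a real change. Compound 3 `O=C(NCc1cn(Cc2ccc(F)cc2)nn1)c1cn(-c2ccccc2)nc1-c1ccc(F)cc1` gives 14300 nM, the highest of the three numbers, yet its gaps to compound 1 and compound 2 also lie within the ordinary scatter, so the three cannot be ranked against each other.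

Compound 4 `COc1cc(Cn2cc(CNC(=O)c3cn(-c4ccccc4)nc3-c3ccc(F)cc3)nn2)cc(OC)c1OC` has not yet been tested. It differs from compound 3 by one exchange: 3,4,5-trimethoxyphenyl in place of 4-fluorophenyl on a saturated chain carbon bound to an aromatic nitrogen. For the measured compounds named here, the only measured step touching this kind of change is the addition of a methoxy group between compound 1 and compound 2, which barely moved the number. Compound 4 is therefore expected to land close to compound 3, with at most a slight drift toward a lower number; the step of a 1.4-fold lower number from compound 3 to compound 4 (0.16 log units; within the scatter) is the estimated shift. Compound 4 is estimated at 10000 nM, within a range from 4000 nM to 25000 nM.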

Compound 4, concentration for 50% growth inhibition: 5200 nM
The estimate for compound 4 lay 1.9-fold (0.28 log units) above the measured number, within the range that was stated.
By their numbers in this assay, from the lowest: compounds 4, 2, 1 and 3 (each within the scatter of the next, the first and the last beyond it).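

In this assay the step of a 2.8-fold lower number from compound 3 to compound 4 (0.44 log units; beyond the scatter) is modest but beyond the scatter, unlike the step of a 1.2-fold lower number from compound 1 to compound 2 (0.09 log units; within the scatter) that came before it. This shows that the group on a saturated chain carbon bound to an aromatic nitrogen can shift the number measurably when 3,4,5-trimethoxyphenyl replaces 4-fluorophenyl, an exchange that brings in 3 hydrogen-bond acceptors where there were 0. No measurement shown explains why the number fell.

On these data alone, it remains open how many of the methoxy groups the shift requires, as compound 1 and compound 2 carry fewer of them but also lack the fluorine of compound 4. Also open, as far as these compounds go, is how the number would respond to an amine or a carboxylic acid in place of the 3,4,5-trimethoxyphenyl group.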